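The source may hold more compounds than are shown below. What is called first, only, known or untested is meant among the compounds shown, and "the series" means these compounds.

Compound 3 `COC1=CC(=O)c2c(c(COC(=O)c3ccccc3)c(C)n2C)C1=O` stands second highest of the three numbers in a functional assay on V79-379A cells (Cricetulus griseus) for cytotoxicity, read by MTT assay, in the presence of a further agent that is not named here; on this read-out higher numbers stand for weaker inhibition and lower numbers for stronger inhibition. Its nearest neighbour is compound 2 `COC1=CC(=O)c2c(c(COC(=O)c3ccccc3)cn2C)C1=O`, which in this assay gives 40 nM, whereas compound 3 gives 200 nM; furthest away lies compound 1 `COC1=CC(=O)c2c(c(CO)c(C3CC3)n2C)C1=O`, which in this assay gives 820000 nM. Compound 4 `COC1=CC(=O)c2c(c(COC(=O)c3ccccc3)c(C3CC3)n2C)C1=O` has not yet been measured; it differs from compound 3 by cyclopropyl in place of methyl on an aromatic carbon. Going by the values given here, one measured step bears on this change, namely a 5.0-fold higher number from compound 2 to compound 3 (0.70 log units; beyond the scatter), which touched the same aromatic carbon. Among the compounds with values here, compound 1 also carries cyclopropyl on that carbon, but it bears hydroxymethyl where compound 3 bears the benzoate, so the two values of compound 1 and compound 3 show only that this pair differs in more than one place and cannot isolate what cyclopropyl alone does. Since methyl raised the number in the step from compound 2 to compound 3, a group of three carbons in the same place is expected to raise it further, and the step is estimated at a 5.0-fold higher number from compound 3 to compound 4 (0.70 log units; beyond the scatter). Compound 4 is therefore expected to give about 1000 nM in this assay, within a range from 200 nM to 8000 nM.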

Compound 4, half-maximal inhibitory concentration: 1000 nM
Compound 4: the middle estimate sits on the measured number at the digits printed, within the range that was stated.
By their numbers in this assay, from the lowest: compound 2; then compound 3; then compound 4; then compound 1.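

In this assay the change to cyclopropyl gives a 5.0-fold higher number from compound 3 to compound 4 (0.70 log units; beyond the scatter) and so continues on the same aromatic carbon the rise that methyl began. Taken from hydrogen to cyclopropyl, the same carbon shows a 25-fold higher number from compound 2 to compound 4 (1.40 log units; beyond the scatter), so across compound 2, compound 3 and compound 4 the number climbs at each step, beyond the scatter, as the group goes from hydrogen to methyl to cyclopropyl. Compound 4 also gives compound 1 a partner that differs in one place only: with cyclopropyl held on that carbon, benzoyl in place of hydrogen on the oxygen gives an 820-fold lower number from compound 1 to compound 4 (2.91 log units; beyond the scatter), a far larger change than any seen so far at the aromatic carbon, and one that compound 1 and compound 3 could not isolate. Nothing at hand explains why the number moves in this way at either place.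

The compounds shown leave open whether an ethyl, an isopropyl or a phenyl on that aromatic carbon would continue the climb, or whether the rise is particular to methyl and cyclopropyl. They also leave open whether an acetyl group in place of benzoyl on the oxygen would keep the number low.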